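Swapping Cyclohexyl for Naphthyl on a Shared Quinoline Core

The source may hold more compounds than are shown below. What is called first, only, known or untested is meant among the compounds shown, and "the series" means these compounds.

Compound 1 `COc1cccc(CNCCCNc2ccnc3cc(C4CCCCC4)ccc23)c1O` was examined in a physicochemical assay for solubility, with a stated time of 18 h, at pH 7.4 (on this read-out higher numbers stand for higher solubility and lower numbers for lower solubility), where compound 1 gives 4200 nM. Two companions share its core and differ only in the group on the saturated chain carbon bound to the amine nitrogen: compound 2 `COc1ccc(F)cc1CNCCCNc1ccnc2cc(C3CCCCC3)ccc12` gives 4200 nM and compound 3 `c1coc(CNCCCNc2ccnc3cc(C4CCCCC4)ccc23)c1` gives 4200 nM in this assay. Compound 1 stands level with both, its nearest being compound 2 and its furthest compound 3. The steps of no change at the digits printed from compound 1 to compound 2 (within the scatter) and no change at the digits printed from compound 1 to compound 3 (within the scatter) were flat, as was no change at the digits printed from compound 2 to compound 3 (within the scatter).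

Compound 4 `COc1cccc(CNCCCNc2ccnc3cc(-c4cccc5ccccc45)ccc23)c1O` changes a different place: naphthalen-1-yl in place of cyclohexyl on an aromatic carbon. For the measured compounds named here, none of the measured steps touches this aromatic carbon, so they offer no direct guide; they show only that the far end of the chain has been tolerant. Lacking a relevant precedent, the step of a 1.7-fold lower number from compound 1 to compound 4 (0.23 log units; within the scatter) is an estimate with wide uncertainty. Compound 4 is therefore expected to give about 2500 nM, within a range of 700 nM to 6000 nM.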

Compound 4, solubility: 32000 nM
Estimate against measurement, compound 4: 13-fold (1.11 log units) below; measured number above the stated range.
By their numbers in this assay, from the lowest: compounds 1, 2 and 3 (each within the scatter of the next); then compound 4.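

At this aromatic carbon, this assay moves where the chain end had stayed flat: naphthalen-1-yl in place of cyclohexyl gives a 7.6-fold higher number from compound 1 to compound 4 (0.88 log units; beyond the scatter). This is the only step shown that lies beyond the scatter, so the read-out is sensitive to this place in a way that compounds 1, 2 and 3 could not reveal. The data shown offer no measured explanation for the rise.

As far as these compounds go, the step swaps one non-aromatic ring for two aromatic rings and adds heavy atoms at the same time, so it remains open whether a single phenyl ring, naphthalen-2-yl or an amine-bearing group such as morpholine would give a similar number. Also open, from the compounds shown here alone, is whether the groups on the chain carbon remain interchangeable with naphthalen-1-yl in place, as only compound 4 carries it.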